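The compounds below may be only part of what the source reports. "The series", "measured", "known", "first", "only" and "open" are said of these compounds alone.

Measured in an ADME assay on L02 cells (Homo sapiens) for inhibition, read by CCK-8 assay, with a stated time of 48 h; on this read-out higher numbers stand for weaker inhibition of growth and lower numbers for stronger inhibition of growth:
- Compound 1 (`Cc1ccccc1Nc1nc(NCc2ccccc2)ncc1Cl`) gives > 100000 nM as a limit of the assay, not a number.
- Compound 2 (`Cc1ccccc1Nc1nc(NCc2ccncc2)ncc1Cl`) gives > 100000 nM as a limit of the assay, not a number.
- Compound 3 (`Cc1ccccc1Nc1nc(Nc2ccc(N3CCN(C)CC3)cn2)ncc1Cl`) gives 5980 nM as a measured number.

Going by the values given here, compound 3 holds the only true number in this set. The other two results are the limit of > 100000 nM in this assay, at which 2 of the 3 values shown sit, and nothing more. Compound 4 (`Cc1ccccc1Nc1nc(Nc2ccc(N3CCNCC3)cn2)ncc1Cl`) has hydrogen in place of methyl on an amine nitrogen in a ring. Among the compounds with values here, the one measured step is a step that the two limits leave unreadable from compound 1 to compound 2 and it concerns a different group, so it offers no size to carry over. No shift beyond the usual scatter is therefore expected in this assay for this change, in either direction. The expected size is a 1.0-fold higher number from compound 3 to compound 4 (0.00 log units; within the scatter) as estimated here. Compound 4 is estimated at 6000 nM within a range from 2500 nM to 15000 nM in this assay.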

Compound 4, concentration for 50% growth inhibition: 1850 nM
The estimate for compound 4 lay 3.2-fold (0.51 log units) above the measured number; measured number below the stated range.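

In this assay the change from 4-methylpiperazin-1-yl to piperazin-1-yl is a 3.2-fold lower number from compound 3 to compound 4 (0.51 log units; beyond the scatter), toward stronger inhibition of growth. Going by these compounds alone, this shows that a change at this ring nitrogen can move the read-out beyond the usual scatter, whereas the one earlier step cannot be read. Nothing shown here gives a reason for this shift.

Only methyl and hydrogen are shown on this nitrogen. An ethyl group, an acetyl group or a longer chain there could fall on either side of compound 3 and compound 4.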